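The compounds below may be only part of what the source reports. "The series", "measured", "known", "first", "only" and "open" are said of these compounds alone.

Measured so far: compound 2 `CN(C(=O)NC(=O)c1cccc(C(F)(F)F)c1)c1nc(C(F)(F)F)c(C(=O)N/N=C/c2cc(C(F)(F)F)cc(C(F)(F)F)c2)s1` gives 5.38 ug/mL; compound 3 `CN(C(=O)NC(=O)c1ccc(C(F)(F)F)cc1)c1nc(C(F)(F)F)c(C(=O)N/N=C/c2cc(C(F)(F)F)cc(C(F)(F)F)c2)s1` gives 8.35 ug/mL; compound 1 `CN(C(=O)NC(=O)c1ccc(Cl)cc1Cl)c1nc(C(F)(F)F)c(C(=O)N/N=C/c2cccc(C(F)(F)F)c2)s1` gives 11.2 ug/mL, all in a functional assay on HepG2 cells (Homo sapiens) for inhibition, read by MTT assay, with a stated time of 72 h; on this read-out higher numbers stand for weaker inhibition and lower numbers for stronger inhibition.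

Among these three, compound 2 shows the lowest number in this assay; its gap to compound 3 is within the scatter, while compound 1 differs from it in two places and shows a higher number. Compound 4 `CN(C(=O)NC(=O)c1cccc(C(F)(F)F)c1)c1nc(C(F)(F)F)c(C(=O)N/N=C/c2cccc(C(F)(F)F)c2)s1` arises from compound 2 by hydrogen in place of trifluoromethyl on an aromatic carbon. Among the compounds with values here, only one single-place step has been measured, a 1.6-fold higher number from compound 2 to compound 3 (0.19 log units; within the scatter), and it concerns the other aryl group, so it does not speak directly to this change. Within the data shown here, with no step bearing on it, the expectation is no change beyond the scatter: a 1.3-fold higher number from compound 2 to compound 4 (0.11 log units; within the scatter). Compound 4 is therefore estimated at 7 ug/mL, within 3.5 ug/mL to 14 ug/mL.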

Compound 4, half-maximal inhibitory concentration: 5.79 ug/mL
The estimate for compound 4 lay 1.2-fold (0.08 log units) above the measured number; low and high end bracket the measured number.
By their numbers in this assay, from the lowest: compounds 2, 4, 3 and 1 (each within the scatter of the next, the first and the last beyond it).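

The step of a 1.1-fold higher number from compound 2 to compound 4 (0.03 log units; within the scatter) in this assay shows that one of the two trifluoromethyl groups on this ring can give way to hydrogen with no change beyond the scatter. On the other aryl group, 3-(trifluoromethyl)phenyl in place of 2,4-dichlorophenyl gives a 1.9-fold lower number from compound 1 to compound 4 (0.29 log units; within the scatter) and likewise stays inside the scatter. No measurement here explains why either change does so little.

Going by these compounds, whether an amine, a carboxylic acid or a longer chain would be tolerated at this place stays open. So does the effect of replacing the remaining trifluoromethyl group on this ring.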